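The compounds below may be only part of what the source reports. "The series", "measured", "known", "first", "only" and "open" are said of these compounds alone.

Three compounds share one core, and their results in a functional assay on HeLa cells (Homo sapiens) for cytotoxicity, read by CCK-8 assay, with a stated time of 72 h (on this read-out higher numbers stand for weaker inhibition and lower numbers for stronger inhibition), set the scene for a fourth. Compound 1 `COc1ccccc1/C=c1/[nH]c(=O)/c(=C\c2cccc(Cl)c2Cl)[nH]c1=O` is reported in this assay as "not active" (no number reported), with no number attached. Compound 2 `C=CCn1c(=O)/c(=C\c2ccc(Cl)c(Cl)c2)[nH]c(=O)/c1=C\c1ccccc1OC` stands in the same place: in this assay compound 2 is reported as "not active" (no number reported), again without a number. Only compound 3 `COc1ccccc1/C=c1\c(=O)[nH]/c(=C/c2cccc(Cl)c2Cl)c(=O)n1C` carries a value, giving 200 nM in this assay. So compound 2 belongs to the pair for which the read-out yielded no figure at all.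

Compound 4 `C=CCn1c(=O)/c(=C\c2ccc(F)c(Br)c2)[nH]c(=O)/c1=C\c1ccccc1OC` is the untested member. It departs from compound 2 by one change: 3-bromo-4-fluorophenyl in place of 3,4-dichlorophenyl on a double-bonded chain carbon bound to an aromatic carbon. Among the compounds with values here, with compound 2 itself reported as "not active" (no number reported), there is no measured step to lean on, and one halogen-bearing ring swapped for another is a modest alteration. No shift beyond the scatter is expected in this assay; the most likely outcome is that compound 4 also returns no number. As a guarded figure, compound 4 is estimated at 20000 nM, within a range from 3000 nM to 100000 nM.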

Compound 4, half-maximal inhibitory concentration: "not active" (no number reported)
For compound 4 the study gives words and no number; there is nothing to compare the estimate with.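

In this assay compound 2 gives "not active" (no number reported) and compound 4 gives "not active" (no number reported), so no step can be read between them. No other evidence bears on this result. The compounds shown leave open whether 3-bromo-4-fluorophenyl and 3,4-dichlorophenyl differ in effect at all.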